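From 4-bromophenyl to 3-methoxyphenyl

The compounds below may be only part of what the source reports. "The series", "measured", "known", "first", "only" and "open" are said of these compounds alone.

For the measured compounds named here, in a functional assay on L1210 cells (Mus musculus) for antiproliferative activity, with a stated time of 48 h (on this read-out higher numbers stand for weaker inhibition and lower numbers for stronger inhibition), compound 1 (`C=C(Br)C(=O)Nc1ccc(/C=C/C(=O)c2ccc(Br)cc2)cc1`) gives 620 nM, the lower of the two numbers measured so far. Compound 2 (`C=C(Br)C(=O)Nc1ccc(/C=C/C(=O)c2ccc(C)cc2)cc1`) gives 1900 nM. Going by the values given here, the only measured step, a 3.1-fold higher number from compound 1 to compound 2 (0.49 log units; beyond the scatter), puts methyl in place of bromo on an aromatic carbon. Compound 3 (`C=C(Br)C(=O)Nc1ccc(/C=C/C(=O)c2cccc(OC)c2)cc1`) has 3-methoxyphenyl in place of 4-bromophenyl on a carbonyl carbon. Among the compounds with values here, it also loses the bromo group, but no measured compound carries methoxy, so a somewhat smaller move toward a higher number is expected in this assay. The expected change is a 2.1-fold higher number from compound 1 to compound 3 (0.32 log units; beyond the scatter). For compound 3, the estimate is 1300 nM, within an expected range of 450 nM to 3800 nM.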

Compound 3, half-maximal inhibitory concentration: 2100 nM
The estimate for compound 3 lay 1.6-fold (0.21 log units) below the measured number; the measured number falls inside the stated range.
By their numbers in this assay, from the lowest: compound 1; then compounds 2 and 3 (each within the scatter of the next).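

In this assay, 3-methoxyphenyl in place of 4-bromophenyl on a carbonyl carbon gives a 3.4-fold higher number from compound 1 to compound 3 (0.53 log units; beyond the scatter). Against 4-methylphenyl, the same group gives a 1.1-fold higher number from compound 2 to compound 3 (0.04 log units; within the scatter), so two different replacements for 4-bromophenyl leave compound 2 and compound 3 indistinguishable here. No measurement available explains these differences.

Compound 3 differs from compound 1 in both the substituent and its ring position, so these two changes cannot be separated. On these data alone, how 3-bromophenyl, 4-methoxyphenyl or a ring carrying an amine would behave remains open.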